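Sulfonyl Substituent Exchanged: Compound 3 to Compound 4

The compounds below may be only part of what the source reports. "The series", "measured", "known", "first", "only" and "open" are said of these compounds alone.

Of the compounds shown here, three in this set have been measured for their minimum effective dose. Compound 1 `CCC(CC)(CC)/N=C(\NC#N)Nc1cccnc1` gives 1 mg/kg in a functional assay on the whole organism (blood, strain Wistar-Okamoto) with Rattus norvegicus as the target, with a stated time of 5 days (a lower number here means that less compound is needed, a higher number that more compound is needed for the effect), and compound 2 `N#CN/C(=N\Cc1ccccc1)Nc1ccncc1` gives 5 mg/kg in this assay. Compound 3 `CCCN(CCC)S(=O)(=O)/N=C(/Nc1cccnc1)NC(C)(C)CC` stands apart from these two: in this assay compound 3 reached only > 50 mg/kg, which is a limit of the assay and not a number. Within the data shown here, that limit is where the limit of > 50 mg/kg in this assay, at which 1 of the 3 values shown sits, places one of the three values, so compound 3 is the one compound whose dose could not be pinned down, while compound 1 and compound 2 both returned a numerical dose.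

Compound 4 `CCC(C)(C)N/C(=N\S(=O)(=O)c1ccc(C)cc1)Nc1cccnc1` is the next compound to be tested in this assay. It differs from compound 3 in one place: 4-methylphenyl in place of dipropylamino on a sulfonyl sulfur. The exchange sits on the sulfonyl sulfur whose other neighbour is the sulfonamide nitrogen, and everything else in the molecule is kept.

Because compound 3 is known only as a limit, the size of any step from it cannot be fixed from the data. The author nevertheless expects a step downward, toward a measurable dose, of about an at least 1.6-fold lower number from compound 3 to compound 4 (0.22 log units; that floor lies within the scatter). Compound 4 is therefore estimated to give 30 mg/kg in this assay, with a range from 5 mg/kg to 100 mg/kg.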

Compound 4, minimum effective dose: > 50 mg/kg
Compound 4: only a limit was reported; the forecaster's own chance of this, stated with the estimate: 45%; at least 1.6-fold (0.22 log units) between middle value and limit.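

Compound 3 and compound 4 are both known in this assay only as limits of the assay, so no step can be read between them: the limit of > 50 mg/kg in this assay, at which 2 of the 4 values shown sit.

The compounds shown leave open what minimum effective dose either compound would have, and whether 4-methylphenyl in place of dipropylamino on a sulfonyl sulfur changes that dose at all.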